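A few compounds are considered here, and "the series" means these few. Any claim that something is new, unique, unknown or untested is made for them only; others in the source may bear on it.

Measured so far in a functional assay on HeLa cells (Homo sapiens) for inhibition; a higher number here means a weaker inhibitor, a lower number a stronger inhibitor:
compound 1 `CC(C)=CCC/C(C)=C/C[C@]12C[C@@H](CC=C(C)C)C(C)(C)[C@](CC=C(C)C)(C(=O)C(C(=O)c3ccc(O)c(O)c3)=C1O)C2=O` gives 11.7 ug/mL
compound 2 `CC(C)=CCC/C(C)=C/C[C@@H]1C[C@]2(C/C=C(\C)CCC=C(C)C)C(=O)[C@@](CC=C(C)C)(C(=O)C(C(=O)c3ccc(O)c(O)c3)=C2O)C1(C)C` gives 8.09 ug/mL
compound 3 `CC(C)=CCC/C(C)=C/C[C@]12C[C@@H](CC=C(C)C)C(C)(C)[C@](C/C=C(\C)CCC=C(C)C)(C(=O)CC1=O)C2=O` gives only a limit of this assay, > 20 ug/mL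

Of the two numbers, compound 1 has the higher one, and the step of a 1.4-fold lower number from compound 1 to compound 2 (0.16 log units; within the scatter), which adds a 3-methylbut-2-en-1-yl group, stays within the usual scatter. Compound 4 `CC(C)=CC[C@@H]1C[C@]2(CC=C(C)C)C(=O)[C@@](CC=C(C)C)(C(=O)C(C(=O)c3ccc(O)c(O)c3)=C2O)C1(C)C` has not yet been measured in this assay. It differs from compound 1 by hydrogen in place of 3-methylbut-2-en-1-yl on a saturated chain carbon bound to a double-bonded chain carbon. Among the measured compounds shown here, the only measured step at this kind of place is the one from compound 1 to compound 2, and it stayed within the scatter; the value of compound 3 is a limit of > 20 ug/mL in this assay, at which 1 of the 3 values shown sits, and gives no step. A step no larger than the scatter, in either direction, is therefore expected. Compound 4 is estimated at 12 ug/mL, between 6 ug/mL and 25 ug/mL, which means a 1.0-fold higher number from compound 1 to compound 4 (0.01 log units; within the scatter).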

Compound 4, half-maximal inhibitory concentration: 13.7 ug/mL
The estimate for compound 4 lay 1.1-fold (0.06 log units) below the measured number, and the stated range covers the measured number.
By their numbers in this assay, from the lowest: compounds 2, 1 and 4 (each within the scatter of the next). At a limit, above all of these: compound 3.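

Shortening the chain at this place, a saturated chain carbon bound to a double-bonded chain carbon, gives a 1.2-fold higher number from compound 1 to compound 4 (0.07 log units; within the scatter) in this assay. Lengthening it gave a 1.4-fold lower number from compound 1 to compound 2 (0.16 log units; within the scatter), so the change has now been read in both directions, and neither step leaves the scatter. Among compounds 1, 2 and 4, the number therefore does not respond to the length of this chain.

Going by these compounds, whether an amine or a carboxylic acid at this place would move the number stays open. Compound 3 gives only a limit, so its steps cannot be read: the limit of > 20 ug/mL in this assay, at which 1 of the 4 values shown sits.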